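The source may hold more compounds than are shown below. What is called first, only, known or untested is meant among the compounds shown, and "the series" means these compounds.

Measured compounds:

compound 1 `O=C([C@@H]1CCCN(S(=O)(=O)c2ccc(S(=O)(=O)C3CCC3)cc2)C1)N1CCC(F)(F)CC1` — 78 nM
compound 2 `CCN(CC)S(=O)(=O)c1ccc(S(=O)(=O)N2CCC[C@@H](C(=O)N3CCC(F)(F)CC3)C2)cc1` — 120 nM

In a functional assay on BXPC-3 cells (Homo sapiens) for inhibition, read by MTT assay, with a stated time of 7 days (a lower number here means a stronger inhibitor, a higher number a weaker inhibitor), compound 2 gives 120 nM and compound 1 gives 78 nM. For the measured compounds named here, of the two numbers that of compound 2 is the larger, but the only step, a 1.5-fold higher number from compound 1 to compound 2 (0.19 log units; within the scatter), lies within the scatter, so the two compounds cannot be told apart on these data.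

Compound 3 `CC(C)NS(=O)(=O)c1ccc(S(=O)(=O)N2CCC[C@@H](C(=O)N3CCC(F)(F)CC3)C2)cc1` keeps the shared core and differs from compound 2 by isopropylamino in place of diethylamino on a sulfonyl sulfur. Going by the values given here, the one step that bears on this position, a 1.5-fold higher number from compound 1 to compound 2 (0.19 log units; within the scatter), exchanged the group on the same sulfonyl sulfur and stayed within the scatter. Nothing here points to a shift beyond the scatter for the present exchange either.

The step expected is a 1.1-fold higher number from compound 2 to compound 3 (0.03 log units; within the scatter), no change beyond the scatter. Compound 3 is therefore estimated at 130 nM, with a range from 60 nM to 280 nM.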

Compound 3, half-maximal inhibitory concentration: 470 nM
The estimate for compound 3 lay 3.6-fold (0.56 log units) below the measured number; measured number outside the range, above it.
By their numbers in this assay, from the lowest: compounds 1 and 2 (each within the scatter of the next); then compound 3.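

In this assay, the group on this sulfonyl sulfur does register: isopropylamino in place of diethylamino gives a 3.9-fold higher number from compound 2 to compound 3 (0.59 log units; beyond the scatter), and isopropylamino in place of cyclobutyl gives a 6.0-fold higher number from compound 1 to compound 3 (0.78 log units; beyond the scatter), whereas cyclobutyl and diethylamino could not be told apart. Isopropylamino carries a hydrogen-bond donor that diethylamino lacks, but the alkyl groups on the nitrogen change in the same exchange, so these compounds do not separate the two differences. No measurement available here accounts for the higher number of compound 3.

As far as these compounds go, whether the hydrogen on the sulfonamide nitrogen or the change of alkyl groups goes with this step remains open. An N-isopropyl-N-methylamino group and a dimethylamino group on the same sulfonyl sulfur would bear on that question.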